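Replacing 4-fluorophenyl with 3-cyanophenyl on the shared core

The source may hold more compounds than are shown below. What is called first, only, known or untested is meant among the compounds shown, and "the series" means these compounds.

In a toxicity assay on MT4 cells (Homo sapiens) for cytotoxicity, read by MTT assay (a lower number here means that less compound is tolerated, a higher number that more compound is tolerated), compound 1 (`Cc1cc(-c2ccccc2)ccc1Oc1cc(N)nc(Nc2ccc(C#N)cc2)n1`) gives 20000 nM while compound 2 (`Cc1cc(-c2cccc(F)c2)ccc1Oc1cc(N)nc(Nc2ccc(C#N)cc2)n1`) gives 11300 nM and compound 3 (`Cc1cc(-c2ccc(F)cc2)ccc1Oc1cc(N)nc(Nc2ccc(C#N)cc2)n1`) gives 20100 nM with all three within the scatter of one another. Compound 4 (`Cc1cc(-c2cccc(C#N)c2)ccc1Oc1cc(N)nc(Nc2ccc(C#N)cc2)n1`) differs from compound 3 by carrying 3-cyanophenyl in place of 4-fluorophenyl on an aromatic carbon. The step of a 1.8-fold lower number from compound 1 to compound 2 (0.25 log units; within the scatter) and the step of a 1.0-fold higher number from compound 1 to compound 3 (0.00 log units; within the scatter) and the step of a 1.8-fold higher number from compound 2 to compound 3 (0.25 log units; within the scatter) all stay within the scatter, and none of them brings in 3-cyanophenyl, so no step beyond the scatter is expected in this assay here. The estimated step is a 1.3-fold lower number from compound 3 to compound 4 (0.13 log units; within the scatter) and it is expected to stay within the scatter. For compound 4 the expected value is 15000 nM with an estimated range from 7000 nM to 30000 nM overall.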

Compound 4, half-maximal cytotoxic concentration: 27400 nM
Compound 4: the middle estimate sits 1.8-fold (0.26 log units) below what was measured, and the stated range covers the measured number.
By their numbers in this assay, from the lowest: compounds 2, 1, 3 and 4 (each within the scatter of the next, the first and the last beyond it).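

Within the data shown here, at this position on the shared core, cyano in place of fluoro gives the only step beyond the scatter in this assay (a 2.4-fold higher number from compound 2 to compound 4 (0.38 log units; beyond the scatter)), a modest one toward more compound being tolerated. Against the plain phenyl and the 4-fluorophenyl, 3-cyanophenyl stays within the scatter (a 1.4-fold higher number from compound 1 to compound 4 (0.14 log units; within the scatter)) and (a 1.4-fold higher number from compound 3 to compound 4 (0.13 log units; within the scatter)), so only the comparison with the 3-fluorophenyl compound separates them. Nothing available bears on why this step appears.

The compounds shown leave open how an amine or a carboxylic acid on this ring would read in this assay.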